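Notes on compound 4: cyano in place of methoxycarbonyl

The source may hold more compounds than are shown below. What is called first, only, known or untested is meant among the compounds shown, and "the series" means these compounds.

For the measured compounds named here, compound 3 `COC(=O)[C@H]1C[C@@H](c2coc3ccc(Cl)cc3c2=O)N(c2ccccc2)O1` is one of three compounds measured in a functional assay on PC-3 cells (Homo sapiens) for inhibition, read by sulforhodamine B assay, with a stated time of 48 h; on this read-out higher numbers stand for weaker inhibition and lower numbers for stronger inhibition. In this assay compound 3 reaches only the limit > 60000 nM. Compound 1 `COC(=O)[C@H]1C[C@@H](c2coc3ccccc3c2=O)N(c2ccccc2)O1` likewise reaches only the limit > 60000 nM. Compound 2 `O=c1c([C@@H]2C[C@H](c3ccccc3)ON2c2ccccc2)coc2cc(Cl)c(Cl)cc12` gives 32000 nM in this assay. The step that the two limits leave unreadable from compound 1 to compound 3 cannot be read because of the limit of > 60000 nM in this assay, at which 2 of the 3 values shown sit. Compound 4 `N#C[C@H]1C[C@@H](c2coc3ccc(Cl)cc3c2=O)N(c2ccccc2)O1` differs from compound 3 by cyano in place of methoxycarbonyl on a saturated ring carbon. No measured step covers this change; the only step shown is unreadable. The step of a number no higher from compound 3 to compound 4 (the limit leaves the size open) expected here is therefore set as none beyond the scatter, with no direction. Compound 4 is expected at 60000 nM, within 20000 nM to 200000 nM, most likely again reported only as a limit.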

Compound 4, half-maximal inhibitory concentration: 41000 nM
Estimate against measurement, compound 4: 1.5-fold (0.17 log units) above, within the range that was stated.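

In this assay, exchanging methoxycarbonyl for cyano on this saturated ring carbon gives an at least 1.4-fold lower number from compound 3 to compound 4 (0.16 log units; that floor lies within the scatter). The smaller cyano group therefore keeps the compound within the measurable range, but that floor shows no gain beyond the scatter. Compound 3 has only a limit, and the true size of the step stays open because of it: the limit of > 60000 nM in this assay, at which 2 of the 4 values shown sit.

From the compounds shown here alone, whether a carboxylic acid, a primary amide or an aminomethyl group on this carbon would shift the number remains open. Also open, going by these compounds, is whether cyano acts alike without the chloro group.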